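Compound 3 and the Isopropyl Step in Lipophilicity

The source may hold more compounds than are shown below. What is called first, only, known or untested is meant among the compounds shown, and "the series" means these compounds.

Of the compounds shown here, two have been measured so far. In a physicochemical assay for lipophilicity, at pH 7.4 (on this read-out lower numbers stand for lower lipophilicity and higher numbers for higher lipophilicity), compound 1 `c1ccc(NC2=NCCC3(CCCCC3)S2)cc1` gives 1.69, and compound 2 `Cc1ccc(NC2=NCCC3(CCCCC3)S2)cc1` gives 1.48. Going by the values given here, the one step between them, a number 0.21 log units lower from compound 1 to compound 2 (within the scatter), is the only precedent available. Compound 2 thus holds the lowest of the two numbers in this assay, with compound 1 nearest to it.

Compound 3 `CC(C)c1ccc(NC2=NCCC3(CCCCC3)S2)cc1` is not yet measured. It differs from compound 2 by isopropyl in place of methyl on an aromatic carbon. Among the compounds with values here, the only measured step that bears on this change is the small one from compound 1 to compound 2, which stayed within the scatter, and no measured pair shows what an isopropyl does on this core. On that basis compound 3 is expected to come out somewhat higher than compound 2, with an estimated step of a number 0.42 log units higher from compound 2 to compound 3 (beyond the scatter), though with little confidence in its size. In this assay compound 3 is therefore estimated at 1.9, within a range from 1.2 to 2.6.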

Compound 3, distribution coefficient: 1.45
For compound 3 the middle estimate is 0.45 log units above the measured one, and the stated range covers the measured number.
By their numbers in this assay, from the lowest: compounds 3, 2 and 1 (each within the scatter of the next).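

With isopropyl in place of methyl on an aromatic carbon, para to a large group, this assay gives a number 0.03 log units lower from compound 2 to compound 3 (within the scatter), and with isopropyl in place of hydrogen at the same place it gives a number 0.24 log units lower from compound 1 to compound 3 (within the scatter). Hydrogen, methyl and isopropyl at this position are thus not separated by this read-out, and compounds 1, 2 and 3 form a set with no exception among them, whereas the earlier pair offered only a single step between hydrogen and methyl. No measurement at hand explains why the larger alkyl group leaves the number within the scatter.

These three compounds carry only hydrogen or alkyl groups at this place, so they leave open what an amine or a carboxylic acid would do there. They also leave open whether a longer chain, such as hexyl, would stay within the scatter of compound 1.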